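Notes on the step from compound 3 to compound 4

The source may hold more compounds than are shown below. What is called first, only, known or untested is meant among the compounds shown, and "the series" means these compounds.

- Compound 1 `Cc1cn([C@@H]2O[C@H](CO[Si](C)(C)C(C)(C)C)[C@@]3(OS(=O)(=O)C=C3N)[C@H]2O[Si](C)(C)C(C)(C)C)c(=O)n(CCCN(CC(=O)O)CC(=O)O)c1=O` gives 123000 nM
- Compound 2 `CNC(=O)CCCCn1c(=O)c(C)cn([C@@H]2O[C@H](CO[Si](C)(C)C(C)(C)C)[C@@]3(OS(=O)(=O)C=C3N)[C@H]2O[Si](C)(C)C(C)(C)C)c1=O` gives > 250000 nM, which is a limit of the assay
- Compound 3 `Cc1cn([C@@H]2O[C@H](CO[Si](C)(C)C(C)(C)C)[C@@]3(OS(=O)(=O)C=C3N)[C@H]2O[Si](C)(C)C(C)(C)C)c(=O)n(/C=C\CO)c1=O` gives 36000 nM

In an ADME assay on MT4 cells (Homo sapiens) for inhibition (a higher number here means that more compound is tolerated, a lower number that less compound is tolerated), compound 3 has the lower of the two true numbers at 36000 nM. For the measured compounds named here, the only other true number belongs to compound 1, and the gap is a 3.4-fold lower number from compound 1 to compound 3 (0.53 log units; beyond the scatter).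

Compound 4 `Cc1cn([C@@H]2O[C@H](CO[Si](C)(C)C(C)(C)C)[C@@]3(OS(=O)(=O)C=C3N)[C@H]2O[Si](C)(C)C(C)(C)C)c(=O)n(CC(N)=O)c1=O` is the next to be measured in this assay. The change is carbamoylmethyl in place of 3-hydroxyprop-1-en-1-yl on an aromatic nitrogen.

Two measured steps bring in 3-hydroxyprop-1-en-1-yl at this same nitrogen. They replace 3-(bis(carboxymethyl)amino)propyl in a 3.4-fold lower number from compound 1 to compound 3 (0.53 log units; beyond the scatter) and 4-(methylcarbamoyl)butyl in an at least 6.9-fold lower number from compound 2 to compound 3 (0.84 log units; beyond the scatter). Both lower the number, so a modest rise is expected when that group leaves. The step between the two other chains, an at least 2.0-fold higher number from compound 1 to compound 2 (0.30 log units; that floor lies within the scatter), adds little. Going by the values given here, no measured compound carries carbamoylmethyl, so the size of the rise is loosely held and the range is wide.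

The estimated change is a 2.5-fold higher number from compound 3 to compound 4 (0.40 log units; beyond the scatter), upward. The expected value for compound 4 is 90000 nM, with an estimated range of 35000 nM to 230000 nM.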

Compound 4, half-maximal cytotoxic concentration: 18000 nM
Compound 4: the middle estimate sits 5.0-fold (0.70 log units) above what was measured; measured number below the stated range.
By their numbers in this assay, from the lowest: compounds 4 and 3 (each within the scatter of the next); then compound 1. At a limit, above all of these: compound 2.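

In this assay, carbamoylmethyl and 3-hydroxyprop-1-en-1-yl on the aromatic nitrogen cannot be told apart, with a 2.0-fold lower number from compound 3 to compound 4 (0.30 log units; within the scatter), so an amide end and an unsaturated alcohol end give comparable numbers on these short groups. Both longer chains stand well clear of the new compound, with a 6.8-fold lower number from compound 1 to compound 4 (0.83 log units; beyond the scatter) and an at least 13-fold lower number from compound 2 to compound 4 (1.14 log units; beyond the scatter), so among the four compounds the two short groups sit low and the two longer chains sit high, and an amide end alone does not carry the higher number, as the amide-ended compound 2 and compound 4 differ widely. The size of the last step is only a floor, as the number for compound 2 is a limit: the limit of > 250000 nM in this assay, at which 1 of the 4 values shown sits.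

The compounds shown leave open whether chain length or the end group sets the number, as length and end group change together across these four. A plain propyl chain, a short chain ending in a carboxylic acid and a longer chain ending in an unsubstituted amide would separate the two.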